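This account rests on a few compounds, and the source may have more. Where it says the series, first, only, none or still open, it means among the compounds named here.

Measured compounds:

Compound 1 `O=C(NC[C@@H]1CC(Br)=NO1)[C@@H]1C[C@@H](c2ccc(O)cc2)CN1C(=O)OCc1cnc2ccccc2c1` gives 0.25 h in an ADME assay on the whole organism (strain CD-1) for metabolic stability, with Mus musculus as the target, at a dose of 50 mg/kg by the oral route; a lower number here means that the compound disappears faster, a higher number that the compound lasts longer.
Compound 2 `O=C(N[C@@H]1C[C@@H](C(=O)NC[C@@H]2CC(Br)=NO2)N(C(=O)OCc2cnc3ccccc3c2)C1)c1cccnc1` gives 0.25 h in this assay.

Among the compounds with values here, compound 2 stands level with compound 1 in this assay, and the one measured step, no change at the digits printed from compound 1 to compound 2 (within the scatter), is within the scatter. The unmeasured compound 3 `O=C(NC[C@@H]1CC(Br)=NO1)[C@@H]1C[C@@H](OCc2ccccc2)CN1C(=O)OCc1cnc2ccccc2c1` differs from compound 2 by benzyloxy in place of ((pyridin-3-yl)carbonyl)amino on a saturated ring carbon. Within the data shown here, no measured step covers a benzyloxy group, and the only step available, from compound 1 to compound 2, concerns an exchange at the same saturated ring carbon that left the half-life unchanged. Among the measured compounds shown here, with that step as the sole guide, no change beyond the scatter is expected in this assay, and the step of no change at the digits printed from compound 2 to compound 3 (within the scatter) is estimated accordingly. Compound 3 is therefore expected to give about 0.25 h, with a range from 0.12 h to 0.5 h.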

Compound 3, half-life: 0.25 h
The estimate for compound 3 equals the measured number at the digits printed, within the range that was stated.
By their numbers in this assay, from the lowest: compounds 1, 2 and 3 (each within the scatter of the next).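

In this assay, the third group on this saturated ring carbon adds two more readings: benzyloxy in place of ((pyridin-3-yl)carbonyl)amino shows no change at the digits printed from compound 2 to compound 3 (within the scatter), and benzyloxy in place of 4-hydroxyphenyl shows no change at the digits printed from compound 1 to compound 3 (within the scatter). The entering benzyloxy has 0 hydrogen-bond donors where the group in compound 2 has 1, and a ring of carbon only where that group has a ring with 1 hetero atom, yet among these compounds neither difference goes with a shift in half-life. Nothing available here offers an explanation for this level reading.

From the compounds shown here alone, all three compounds carry a six-membered aromatic ring in the group at this position, so what an amine or a carboxylic acid would do there remains open. Going by these compounds, whether a change elsewhere on the shared core would shift the half-life remains open as well.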